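The source may hold more compounds than are shown below. What is called first, only, known or untested is meant among the compounds shown, and "the series" means these compounds.

Values measured so far in an ADME assay (liver) for metabolic stability, with Liver microsome (Rattus norvegicus) as the target, using microsomes and NADPH, with a stated time of 30 min, tested at 1 uM; on this read-out lower numbers stand for slow clearance and higher numbers for fast clearance:
Compound 1 `Nc1ccc(S(=O)(=O)N2CCN(c3ncc(C(O)(C(F)(F)F)C(F)(F)F)cc3C3CC3)CC2)cn1`: 27 mL.min-1.g-1
Compound 2 `Nc1ccc(S(=O)(=O)N2CCN(c3ncc(C(O)(C(F)(F)F)C(F)(F)F)cc3C#CCO)CC2)cn1`: 65 mL.min-1.g-1
Compound 3 `Nc1ccc(S(=O)(=O)N2CCN(c3ncc(C(O)(C(F)(F)F)C(F)(F)F)cc3C#CCCO)CC2)cn1`: 68 mL.min-1.g-1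

Compound 2 stands at the high end of this small set, and the step to its nearest neighbour is a 1.0-fold higher number from compound 2 to compound 3 (0.02 log units; within the scatter). The next change gives compound 4 `Cn1cc(-c2cc(C(O)(C(F)(F)F)C(F)(F)F)cnc2N2CCN(S(=O)(=O)c3ccc(N)nc3)CC2)cn1`: 1-methyl-1H-pyrazol-4-yl in place of 3-hydroxyprop-1-yn-1-yl on an aromatic carbon. In words, 1-methyl-1H-pyrazol-4-yl comes in place of 3-hydroxyprop-1-yn-1-yl on an aromatic carbon. Two measured steps at this place bear on it, a 2.4-fold higher number from compound 1 to compound 2 (0.38 log units; beyond the scatter) and a 2.5-fold higher number from compound 1 to compound 3 (0.40 log units; beyond the scatter). Both were modest, but neither involved an aromatic ring in this place. A small step down, no larger than the scatter, is therefore expected: a 1.3-fold lower number from compound 2 to compound 4 (0.11 log units; within the scatter). For compound 4 the estimate is 50 mL.min-1.g-1, with an expected range from 22 mL.min-1.g-1 to 110 mL.min-1.g-1.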

Compound 4, intrinsic clearance in microsomes: 44 mL.min-1.g-1
Compound 4: the middle estimate sits 1.1-fold (0.06 log units) above what was measured, within the range that was stated.
By their numbers in this assay, from the lowest: compounds 1, 4, 2 and 3 (each within the scatter of the next, the first and the last beyond it).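

In this assay, the first aromatic ring at this position, 1-methyl-1H-pyrazol-4-yl, cannot be told apart from either hydroxy alkyne, with a 1.5-fold lower number from compound 2 to compound 4 (0.17 log units; within the scatter) and a 1.5-fold lower number from compound 3 to compound 4 (0.19 log units; within the scatter). It also cannot be told apart from cyclopropyl, with a 1.6-fold higher number from compound 1 to compound 4 (0.21 log units; within the scatter), even though cyclopropyl and the two alkynes do differ beyond the scatter. Replacing a chain bearing a hydrogen-bond donor with a ring bearing none therefore moves the number no further than the scatter here. Nothing available explains these numbers. On these data alone, how a simple amine or an unsubstituted phenyl ring would behave on this aromatic carbon remains open.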